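Swapping a Side Group on a Piperidine-Based Series

This account rests on a few compounds, and the source may have more. Where it says the series, first, only, none or still open, it means among the compounds named here.

Measured so far:
- compound 1, `COC[C@H](NC1CCN(CCCc2c[nH]c3ccc(Cn4cncn4)cc23)CC1)c1ccc(F)cc1` — 1200 nM
- compound 2, `CC(=O)Nc1ccc(CNC2CCN(CCCc3c[nH]c4ccc(-n5cnnc5)cc34)CC2)cc1` — 45 nM
- compound 3, `CN(Cc1ccco1)C1CCN(CCCc2c[nH]c3ccc(-n4cnnc4)cc23)CC1` — 89 nM

All three compounds were tested in an assay on CHO cells for displacement of a labelled ligand from 5-hydroxytryptamine receptor 1B (Homo sapiens); on this read-out lower numbers stand for stronger inhibition and higher numbers for weaker inhibition. Compound 3 gives 89 nM, the second highest of the three numbers. Its nearest neighbour is compound 2, whose number is lower by an amount that stays within the usual scatter, so the two cannot be told apart. Compound 1 sits far away with a number beyond the scatter, so compound 3 is clearly the stronger of that pair.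

The next compound, compound 4, `c1ccc2c(c1)CCC2NCC1CCN(CCCc2c[nH]c3ccc(-n4cnnc4)cc23)CC1`, has not yet been measured. It differs from compound 3 in one place: ((2,3-dihydro-1H-inden-1-yl)amino)methyl in place of ((furan-2-yl)methyl)(methyl)amino on a saturated ring carbon. The group that leaves carries one five-membered aromatic ring with one hetero atom; the group that enters is larger and brings a hydrogen-bond donor.

Within the data shown here, no comparable step between measured compounds exists, so the expectation rests on the spread of the numbers. Compound 2, which also carries a hydrogen-bond donor on its side group, gives 45 nM, which hints that compound 4 may land at or slightly below compound 3. Compound 4 is therefore expected to give 55 nM, with a range from 15 nM to 200 nM. This estimate means a step of a 1.6-fold lower number from compound 3 to compound 4 (0.21 log units; within the scatter), which is expected to stay within the scatter.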

Compound 4, half-maximal inhibitory concentration: 25 nM
The estimate for compound 4 lay 2.2-fold (0.34 log units) above the measured number; low and high end bracket the measured number.
By their numbers in this assay, from the lowest: compounds 4, 2 and 3 (each within the scatter of the next, the first and the last beyond it); then compound 1.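

In this assay, among these compounds, the swap on the saturated ring carbon gives a 3.6-fold lower number from compound 3 to compound 4 (0.55 log units; beyond the scatter), the first single-place step that can be read. It shows that this position accepts a larger group with a carbon-only ring pair and a hydrogen-bond donor in place of ((furan-2-yl)methyl)(methyl)amino, and that the number falls rather than rises. No measurement shown here accounts for the drop.

From the compounds shown here alone, the step changes the ring type, the size and the hydrogen-bond donor count all at once, so the share of each in the drop remains open. A methyl group on the nitrogen of ((2,3-dihydro-1H-inden-1-yl)amino)methyl, with the rings kept as they are, would separate the role of the hydrogen-bond donor from that of the rings.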